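Expecting Little Change from a Chlorophenyl Substitution

The source may report more compounds than this note shows. Statements on the series, on what has been measured and on what is new or still open speak of the compounds shown alone.

Three measured compounds share one core and differ only at a saturated chain carbon bound to an aromatic nitrogen. Compound 1 `CCCn1cc(COc2cc(O)c3c(c2)O[C@H](c2ccc(OC)c(O)c2)CC3=O)nn1` carries an ethyl there, and in a functional assay on RAW264.7 cells (Mus musculus) for inhibition, read by Griess assay, with stated times of 2 h and 24 h (a higher number here means a weaker inhibitor, a lower number a stronger inhibitor), compound 1 gives 9670 nM. Compound 2 `COc1ccc([C@@H]2CC(=O)c3c(O)cc(OCc4cn(Cc5cccc(C#N)c5)nn4)cc3O2)cc1O` carries a 3-cyanophenyl, and in this assay compound 2 gives 18000 nM. Compound 3 `COc1ccc([C@@H]2CC(=O)c3c(O)cc(OCc4cn(C)nn4)cc3O2)cc1O` carries only hydrogen; in this assay compound 3 gives 15200 nM, the second highest of the three numbers, with compound 2 nearest and compound 1 furthest, both gaps within the scatter. Compound 4 `COc1ccc([C@@H]2CC(=O)c3c(O)cc(OCc4cn(Cc5ccc(Cl)cc5)nn4)cc3O2)cc1O` differs from compound 3 by 4-chlorophenyl in place of hydrogen on a saturated chain carbon bound to an aromatic nitrogen. Within the data shown here, the steps that bear on this are a 1.2-fold lower number from compound 2 to compound 3 (0.07 log units; within the scatter) and a 1.9-fold higher number from compound 1 to compound 2 (0.27 log units; within the scatter): neither exchanging hydrogen for an aromatic ring nor exchanging ethyl for one moved the number beyond the scatter. For compound 4 the expected step is therefore a 1.1-fold higher number from compound 3 to compound 4 (0.02 log units; within the scatter), no more than the scatter in either direction. Compound 4 is expected to give about 16000 nM, with a likely range from 7000 nM to 36000 nM.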

Compound 4, half-maximal inhibitory concentration: 17800 nM
For compound 4 the middle estimate is 1.1-fold (0.05 log units) below the measured one; the range from low to high includes it.
By their numbers in this assay, from the lowest: compounds 1, 3, 4 and 2 (each within the scatter of the next).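

In this assay, 4-chlorophenyl in place of hydrogen gives a 1.2-fold higher number from compound 3 to compound 4 (0.07 log units; within the scatter), in place of 3-cyanophenyl it gives a 1.0-fold lower number from compound 2 to compound 4 (0.00 log units; within the scatter), and in place of ethyl it gives a 1.8-fold higher number from compound 1 to compound 4 (0.26 log units; within the scatter). With a second substituted aromatic ring now in the set, every pair among these four compounds lies within the scatter, so hydrogen, ethyl, 3-cyanophenyl and 4-chlorophenyl on this saturated chain carbon cannot be told apart by this read-out, and no compound goes against that. Nothing at hand explains this sameness.

On these data alone, what stays open is whether any group at this place can move the number beyond the scatter. An amine, a carboxylic acid or a longer chain would test that, in either direction.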